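Growing an Alkyl Chain and Half-Life in Monkey

This account rests on a few compounds, and the source may have more. Where it says the series, first, only, none or still open, it means among the compounds named here.

Of the compounds shown here, two with a shared core have been measured in an ADME assay on the whole organism (Macaca fascicularis) for metabolic stability; on this read-out higher numbers stand for a longer-lived compound and lower numbers for a shorter-lived compound. Compound 1 `CCc1sc(N(CC2CC2)[C@H](C)c2ccc(-c3cc(C)ccc3-c3nc(=O)o[nH]3)cc2)nc1C(=O)NS(=O)(=O)C1CC1` gives 3 h. Compound 2 `Cc1ccc(-c2nc(=O)o[nH]2)c(-c2ccc([C@@H](C)N(CC3CC3)c3nc(C(=O)NS(=O)(=O)C4CC4)c(C(C)C)s3)cc2)c1` gives 2.4 h. Of the two numbers shown, compound 2 differs from compound 1 only by a 1.3-fold lower number from compound 1 to compound 2 (0.10 log units; within the scatter), so the two stand within the scatter of each other.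

Compound 3 `Cc1ccc(-c2nc(=O)o[nH]2)c(-c2ccc([C@@H](C)N(CC3CC3)c3nc(C(=O)NS(=O)(=O)C4CC4)c(CC(C)C)s3)cc2)c1` has not yet been measured. It differs from compound 2 in one place: isobutyl in place of isopropyl on an aromatic carbon. Among the compounds with values here, the one step already seen at that same place, a 1.3-fold lower number from compound 1 to compound 2 (0.10 log units; within the scatter), also added a single carbon to the alkyl chain there and left the number within the scatter. The step from compound 2 to compound 3 is expected to behave alike, giving a change of about a 1.1-fold lower number from compound 2 to compound 3 (0.04 log units; within the scatter) in this assay, with no direction beyond the scatter. Compound 3 is therefore estimated at 2.2 h, within a range from 1.2 h to 4 h.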

Compound 3, half-life: 2.3 h
For compound 3 the middle estimate is 1.0-fold (0.02 log units) below the measured one; low and high end bracket the measured number.
By their numbers in this assay, from the lowest: compounds 3, 2 and 1 (each within the scatter of the next).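

Swapping isopropyl for isobutyl on this aromatic carbon, next to the ring sulfur, gives a 1.0-fold lower number from compound 2 to compound 3 (0.02 log units; within the scatter) in this assay, so a second added carbon at this position also leaves the half-life within the scatter. Taken across the whole series, a 1.3-fold lower number from compound 1 to compound 3 (0.12 log units; within the scatter), and this wider span also stays within the scatter, so among these three compounds neither growing the chain nor branching it further from the ring shows a readable effect on half-life. Nothing at hand explains why this position tolerates these changes.

Going by these compounds, whether a much longer chain such as hexyl, or a chain carrying an amine or a carboxylic acid, would move the half-life beyond the scatter remains open. These three compounds also cannot show how changes elsewhere on the shared core would behave.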